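A few compounds are considered here, and "the series" means these few. Any claim that something is new, unique, unknown or untested is made for them only; others in the source may bear on it.

Measured in a functional assay on SW-620 cells (Homo sapiens) for cytotoxicity; a higher number here means a weaker inhibitor, a lower number a stronger inhibitor:

- Compound 1 `O=C(CCCCCCC(=O)Nc1nc2ccccc2s1)NO`: 4.01 ug/mL
- Compound 2 `CS(=O)(=O)c1ccc2nc(NC(=O)CCCCCCC(=O)NO)sc2c1`: 5.42 ug/mL
- Compound 3 `CS(=O)(=O)c1ccc2nc(NC(=O)CCCCC(=O)NO)sc2c1`: > 30 ug/mL (a limit)

Compound 3 stands at > 30 ug/mL, which is a limit of the assay and not a number. Compound 4 `Cc1ccc2nc(NC(=O)CCCCC(=O)NO)sc2c1` has methyl in place of methylsulfonyl on an aromatic carbon. The closest measured change also concerns the methylsulfonyl group, there exchanged for hydrogen, and gives a 1.4-fold higher number from compound 1 to compound 2 (0.13 log units; within the scatter). That evidence comes only from the longer chain of compound 1 and compound 2. The other measured change, an at least 5.5-fold higher number from compound 2 to compound 3 (0.74 log units; beyond the scatter), alters the chain, and compound 4 keeps the chain of compound 3. No step beyond the scatter is therefore expected in this assay, and compound 4 may again report only a limit. The expected step is a number no higher from compound 3 to compound 4 (the limit leaves the size open). Compound 4 is estimated at 30 ug/mL, with an expected range of 12 ug/mL to 80 ug/mL.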

Compound 4, half-maximal inhibitory concentration: 4.69 ug/mL
Compound 4: the middle estimate sits 6.4-fold (0.81 log units) above what was measured, and the stated range ends above it.
By their numbers in this assay, from the lowest: compounds 1, 4 and 2 (each within the scatter of the next). At a limit, above all of these: compound 3.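

The step of an at least 6.3-fold lower number from compound 3 to compound 4 (0.80 log units; beyond the scatter) shows that in this assay the group on this aromatic carbon can shift the read-out beyond the scatter, which the earlier exchange on the longer chain did not show: there the step was a 1.4-fold higher number from compound 1 to compound 2 (0.13 log units; within the scatter). The shorter chain alone therefore does not take a compound to the limit, since compound 4 keeps the chain of compound 3 and still gives a measured value. Compound 3 stands at a limit, so the full size of this step stays open: the limit of > 30 ug/mL in this assay, at which 1 of the 4 values shown sits.

As far as these compounds go, it remains open whether methylsulfonyl would act the same way on both chains, as the two exchanges differ in both the incoming group and the chain. From the compounds shown here alone, how an amine or a carboxylic acid on this aromatic carbon would read in this assay also remains unknown.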